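The compounds below may be only part of what the source reports. "The series", "measured", "known", "first", "only" and "open" are said of these compounds alone.

Working notes on the series. In an assay for inhibition of Fatty-acid amide hydrolase 1 (Rattus norvegicus) (on this read-out higher numbers stand for weaker inhibition and lower numbers for stronger inhibition), compound 1, `CCCCCCCC/C=C\CCCCCCCC(=O)c1nnc(-c2cccs2)o1`, gives 8 nM, and compound 2, `CCCCCCCC/C=C\CCCCCCCC(=O)c1nncs1`, gives 170 nM. Among the measured compounds shown here, compound 2 thus stands at the highest of the two numbers so far, with compound 1 as its only neighbour on this read-out; the two differ in more than one place, so their values are noted side by side without a computed step. Compound 3, `CCCCCCCC/C=C\CCCCCCCC(=O)c1nnc(-c2ccccn2)s1`, is not yet measured. It is reached from compound 2 by a single change, (pyridin-2-yl in place of hydrogen on an aromatic carbon). For the measured compounds named here, the one measured compound that carries an aromatic group on its core, compound 1, sits at 8 nM, well under compound 2. On that basis compound 3 is expected to move down, the step of an 8.5-fold lower number from compound 2 to compound 3 (0.93 log units; beyond the scatter) being beyond the scatter. The estimate for compound 3 in this assay is 20 nM, in the range 5 nM to 80 nM.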

Compound 3, inhibition constant: 20 nM
Estimate against measurement, compound 3: no gap at the digits printed, and the stated range covers the measured number.
By their numbers in this assay, from the lowest: compound 1; then compound 3; then compound 2.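

In this assay, among the compounds shown here, pyridin-2-yl in place of hydrogen on the aromatic carbon next to the ring sulfur gives an 8.5-fold lower number from compound 2 to compound 3 (0.93 log units; beyond the scatter) and provides the first one-place comparison. This position therefore accepts a six-membered aromatic ring, and inhibition gains from it by more than the scatter, which the side-by-side values of compound 1 and compound 2 could not show for any single place. Nothing at hand accounts for the size of this step.

A phenyl group at this carbon would test whether the pyridine nitrogen matters to the step, and a methyl group would test whether a small substituent is enough. A carboxylic acid on the pyridine ring would show how far this position tolerates further substitution.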